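Phenylpiperidine acetamides: efficacy at the dopamine D4 receptor

The source may hold more compounds than are shown below. What is called first, only, known or untested is meant among the compounds shown, and "the series" means these compounds.

Measured so far in a functional assay on HEK293 cells for agonist activity at D(4) dopamine receptor (Homo sapiens), read by FLIPR; on this read-out higher numbers stand for larger maximal responses and lower numbers for smaller maximal responses:
compound 1 `Cc1cccc(NC(=O)CN2CCC(c3ccc(O)cc3)CC2)c1` gives 60%;
compound 2 `Cc1cccc(NC(=O)CN2CCC(c3ccccc3)CC2)c1` gives 37%;
compound 3 `C=Cc1cccc(C(=O)NCN2CCC(c3cccc[n+]3[O-])CC2)c1` gives 63%.

Compound 2 has the lowest of the three maximal responses. Going by the values given here, the only single-point step in the set runs to it: a number 23 percentage points lower from compound 1 to compound 2 (beyond the scatter). Among the compounds with values here, compound 3 shows a value close to that of compound 1, but it differs from compound 2 in several places at once and no step is computed for that pair.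

Compound 4 `Cc1cccc(NC(=O)CN2CCC(c3ccccc3C#N)CC2)c1` is not yet measured. It differs from compound 2 by cyano in place of hydrogen on an aromatic carbon, placed ortho to a large group. Within the data shown here, no measured step concerns a cyano group, and the one step that does exist concerns a hydroxy group at a different place on the same ring, so it gives only a loose guide: a substituent on that ring raised the maximal response there, and a similar direction is tentatively expected here, with an estimated step of a number 8 percentage points higher from compound 2 to compound 4 (within the scatter). Compound 4 is therefore estimated at 45%, within 25% to 65%, a range wide enough that no change beyond the scatter would also fit.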

Compound 4, largest response reached (reported as efficacy), in percent of the reference or control that the assay uses: 71%
Compound 4: the middle estimate sits 26 percentage points below what was measured; the measured number lies above the stated range.
By their numbers in this assay, from the lowest: compound 2; then compounds 1, 3 and 4 (each within the scatter of the next, the first and the last beyond it).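

In this assay the ring carbon ortho to a large group accepts a substituent, and the change from phenyl to 2-cyanophenyl gives a large rise: a number 34 percentage points higher from compound 2 to compound 4 (beyond the scatter). The 2-cyanophenyl group also compares favourably with the 4-hydroxyphenyl group of the earlier pair, giving a number 11 percentage points higher from compound 1 to compound 4 (beyond the scatter), so the hydroxy group no longer marks the top of this short amide series. Nothing available explains the size of the cyano step.

Going by these compounds, it remains open whether this rise is specific to cyano or would also appear with an amine, a methoxy group or a carboxylic acid at the same place. Also open, on these data alone, is how cyano behaves elsewhere on this ring, and whether the step carries over to the core of compound 3.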